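Removing the Chloro Group from Compound 2

The source may hold more compounds than are shown below. What is called first, only, known or untested is meant among the compounds shown, and "the series" means these compounds.

Of the compounds shown here, two have been measured so far in a functional assay, tested at 2 mM; on this read-out higher numbers stand for more inhibition at the one concentration tested (going by the name of the read-out) and lower numbers for less inhibition. Compound 1 `C/C(=N\N=C1\N=C(c2cc3ccccc3o2)CS1)c1nc(-c2ccccc2)[nH]c1C` gives 39.9% in this assay. Compound 2 `CC1=N/C(=N/N=C(\C)c2nc(-c3ccccc3)[nH]c2C)S/C1=N\Nc1ccc(Cl)cc1` gives 40.7% in this assay. Compound 2 holds the higher of the two numbers, but the gap to compound 1 lies within the scatter of repeated measurements, so the two values cannot be separated on the data in hand.

Compound 3 `CC1=N/C(=N/N=C(\C)c2nc(-c3ccccc3)[nH]c2C)S/C1=N\Nc1ccccc1` has not yet been measured in this assay. It differs from compound 2 in a single place: hydrogen in place of chloro on an aromatic carbon. Among the measured compounds shown here, no pair of measured compounds shows this change, so there is no measured precedent for how the read-out responds to it. Compounds 1 and 2, which differ in other ways, give values close to one another. With nothing pointing to a shift in either direction, the step from compound 2 to compound 3 is expected to be a number 2.7 percentage points lower from compound 2 to compound 3 (within the scatter), a change no larger than the scatter. Compound 3 is therefore estimated to give 38% in this assay, within a range from 24% to 52%.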

Compound 3, a percentage reported as inhibition, at one concentration (the size of the read-out at that concentration, not a potency): 44.4%
Compound 3: middle estimate off by 6.4 percentage points, on the low side; measured number inside the range.
By their numbers in this assay, from the lowest: compounds 1, 2 and 3 (each within the scatter of the next).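

Among the compounds shown here, this is the first measured pair that isolates a single change at this aromatic carbon, para to a large group: in this assay, hydrogen in place of chloro, which turns the 4-chlorophenyl group into phenyl, gives a number 3.7 percentage points higher from compound 2 to compound 3 (within the scatter) and so does not separate the two compounds. On this evidence, the chloro group can be removed from this carbon without a step beyond the usual scatter, although a single pair cannot show how the position responds to other groups. Nothing measured on hand explains the result or shows what the chloro group does at this position.

The compounds shown leave open whether a group different from chloro and hydrogen on this same carbon, such as an amine, a carboxylic acid or a longer alkyl chain, would move the read-out beyond the scatter and in which direction. For the compounds shown here, they also leave open whether the same swap of chloro for hydrogen would give a similarly small step on a different core, since this pair offers only one example of the change.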